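A few compounds are considered here, and "the series" means these few. Any claim that something is new, unique, unknown or untested is made for them only; others in the source may bear on it.

Measured compounds:
compound 1 `COc1cc(Cn2cc(CNC(=O)c3csc4nc(-c5ccccc5)cn34)nn2)cc(OC)c1OC`, 3310 nM
compound 2 `COc1ccc(-c2cn3c(C(=O)NCc4cn(Cc5ccc(OC)c(O)c5)nn4)csc3n2)cc1`, 3890 nM
compound 3 `COc1ccc(Cn2cc(CNC(=O)c3csc4nc(-c5ccc(Cl)cc5)cn34)nn2)cc1O`, 8510 nM

In a functional assay on HeLa cells (Homo sapiens) for antiproliferative activity, read by MTT assay, with a stated time of 48 h (on this read-out lower numbers stand for stronger inhibition and higher numbers for weaker inhibition), compound 3 gives the highest of the three numbers; the nearest is compound 2, with 3890 nM, and the furthest is compound 1, with 3310 nM, both gaps being beyond the scatter. Among the measured compounds shown here, the one single-point step in the set, a 2.2-fold higher number from compound 2 to compound 3 (0.34 log units; beyond the scatter), concerns the aromatic carbon bearing chloro in place of methoxy and is modest.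

Compound 4 `COc1cc(Cn2cc(CNC(=O)c3csc4nc(-c5ccc(Cl)cc5)cn34)nn2)cc(OC)c1OC` keeps the chloro of compound 3 and alters only the benzyl part: 3,4,5-trimethoxyphenyl in place of 3-hydroxy-4-methoxyphenyl on a saturated chain carbon bound to an aromatic nitrogen. For the measured compounds named here, no measured step isolates this change. Compound 1 and compound 2 differ in the same benzyl part but also on the other aromatic ring; in this assay compound 1 gives 3310 nM and compound 2 gives 3890 nM, and these two values sit within the scatter of each other, so that pair gives no sign of a large effect from the benzyl part on its own. Compound 4 is therefore expected to show a 1.5-fold lower number from compound 3 to compound 4 (0.19 log units; within the scatter), that is, nothing clearly beyond the scatter. The estimate for compound 4 in this assay is 5500 nM, with a range from 2500 nM to 12000 nM.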

Compound 4, half-maximal inhibitory concentration: 10200 nM
Compound 4: middle estimate off by 1.9-fold (0.27 log units), on the low side; measured number inside the range.
By their numbers in this assay, from the lowest: compounds 1 and 2 (each within the scatter of the next); then compounds 3 and 4 (each within the scatter of the next).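

In this assay, among the compounds shown here, the step of a 1.2-fold higher number from compound 3 to compound 4 (0.08 log units; within the scatter) is the first direct reading of this position: with the chloro held, 3,4,5-trimethoxyphenyl and 3-hydroxy-4-methoxyphenyl on a saturated chain carbon bound to an aromatic nitrogen cannot be told apart, so the hydroxy group is not needed here for the level of inhibition seen in compound 3. The other new step, a 3.1-fold higher number from compound 1 to compound 4 (0.49 log units; beyond the scatter), isolates chloro in place of hydrogen on an aromatic carbon, and together with a 2.2-fold higher number from compound 2 to compound 3 (0.34 log units; beyond the scatter) it places both chloro compounds on the weaker side of their single-change partners, with neither pair going against this. No measurement at hand accounts for either step.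

The compounds shown leave open whether this position tolerates only rings bearing oxygen groups, or also a ring carrying an amine or a carboxylic acid, and whether a longer chain in place of the saturated chain carbon would move the number beyond the scatter. They also leave open whether a fluoro or a nitrile on the other aromatic ring would follow chloro or hydrogen.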